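Shortening the amine side chain of compound 2

A few compounds are considered here, and "the series" means these few. Any claim that something is new, unique, unknown or untested is made for them only; others in the source may bear on it.

Compound 1, `NCc1nnc(Cc2ccccc2)s1`, gives 200 mg/kg in a functional assay on the whole organism with Mus musculus as the target; a higher number here means that more compound is needed for the effect, a lower number that less compound is needed.
Compound 2, `c1ccc(CNCc2nnc(-c3ccccc3-c3ccccc3)s2)cc1`, gives 29 mg/kg in this assay.
Compound 3, `CNCc1nnc(-c2ccccc2)s1`, gives > 200 mg/kg in this assay, and this value is a limit of the assay.

Compound 2 stands at the lowest of the two numbers measured, and its gap to compound 1 lies beyond the usual scatter. Compound 4, `NCCCc1nnc(-c2ccccc2-c2ccccc2)s1`, differs from compound 2 by 2-aminoethyl in place of benzylamino on a saturated chain carbon bound to an aromatic carbon. Going by the values given here, no measured pair shows this step, but the two compounds without a benzylamino group, compound 1 and compound 3, both sit at the higher end of what has been seen. The step from compound 2 to compound 4 is therefore expected to raise the number, by a 3.4-fold higher number from compound 2 to compound 4 (0.54 log units; beyond the scatter). Compound 4 is estimated at 100 mg/kg, between 30 mg/kg and 300 mg/kg.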

Compound 4, dose for half-maximal effect: > 200 mg/kg
Compound 4 ended at the assay's limit (the forecaster's own chance of this, stated with the estimate: 25%); at least 2.0-fold (0.30 log units) between middle value and limit.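

In this assay, going by these compounds alone, 2-aminoethyl in place of benzylamino on a saturated chain carbon bound to an aromatic carbon gives an at least 6.8-fold higher number from compound 2 to compound 4 (0.83 log units; beyond the scatter), the first matched step at this position. It shows that the benzylamino group cannot be exchanged for 2-aminoethyl here without a clear rise in the number. On these data alone, compound 4 gives > 200 mg/kg, which is a limit of the assay, so the full size of the step stays unknown: the limit of > 200 mg/kg in this assay, at which 2 of the 4 values shown sit.

The compounds shown leave open whether the ring or the chain length matters more. A cyclohexylmethylamino or a phenethylamino group at this place could begin to separate the two.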